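Adding a chloro group to the aryl ring of compound 1

The source may report more compounds than this note shows. Statements on the series, on what has been measured and on what is new or still open speak of the compounds shown alone.

Compound 1 `O=C(O)CCCSCCN1C(=O)OC[C@@H]1/C=C/[C@@H](O)Cc1ccccc1` was tested in an assay on CHO cells for displacement of a labelled ligand from prostaglandin E2 receptor EP4 subtype (Mus musculus), read by scintillation counting, with a stated time of 60 min (on this read-out higher numbers stand for weaker inhibition and lower numbers for stronger inhibition), where compound 1 gives 4.2 nM, the highest of the three numbers; compound 2 `CCc1cccc(C[C@H](O)/C=C/[C@H]2CSC(=O)N2CCSCCCC(=O)O)c1` gives 0.88 nM and compound 3 `O=C(O)CCCSCCN1C(=O)SC[C@@H]1/C=C/[C@@H](O)Cc1cccc(C(F)(F)F)c1` gives 0.97 nM, each lower by more than the scatter. Compound 4 `O=C(O)CCCSCCN1C(=O)OC[C@@H]1/C=C/[C@@H](O)Cc1cccc(Cl)c1` differs from compound 1 by chloro in place of hydrogen on an aromatic carbon. Going by the values given here, no measured pair shows this exact change on the same core. Among the compounds with values here, the only single step, a 1.1-fold higher number from compound 2 to compound 3 (0.04 log units; within the scatter), exchanges one group for another on the aromatic carbon meta to a large group and stays within the scatter. Compounds 2 and 3 carry a group on that carbon and show lower numbers than compound 1, but they also differ in the core. A modestly lower number is therefore expected, a 2.8-fold lower number from compound 1 to compound 4 (0.45 log units; beyond the scatter). Compound 4 is estimated at 1.5 nM, within a range from 0.5 nM to 5 nM.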

Compound 4, inhibition constant: 1.5 nM
Estimate against measurement, compound 4: no gap at the digits printed; measured number inside the range.
By their numbers in this assay, from the lowest: compounds 2, 3 and 4 (each within the scatter of the next); then compound 1.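

In this assay, chloro in place of hydrogen on the aromatic carbon gives a 2.8-fold lower number from compound 1 to compound 4 (0.45 log units; beyond the scatter), so a single added heavy atom at this position is enough for a modest step beyond the scatter. The earlier step only exchanged one group for another there, with no hydrogen-bearing partner on the same core. No measured evidence here accounts for this step.

The compounds shown leave open how a methoxy group or an amine on this carbon would read. They also leave open how chloro would read on another carbon of the ring.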